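The source may hold more compounds than are shown below. What is called first, only, known or untested is meant among the compounds shown, and "the series" means these compounds.

Measured so far:
Compound 1, `COc1ccc(/C=C/c2cc(OC)cc(OC)c2/C=C/C(=O)c2cc3ccc(Br)cc3oc2=O)cc1`, gives 3010 nM in an assay on isolated protein for inhibition of Amine oxidase [flavin-containing] A (Homo sapiens), read by fluorescence, with a stated time of 15 min; on this read-out higher numbers stand for weaker inhibition and lower numbers for stronger inhibition.
Compound 2, `COc1ccc(/C=C/c2cc(OC)cc(OC)c2/C=C/C(=O)c2cc3ccc(Cl)cc3oc2=O)cc1`, reaches only the limit of this assay, > 60000 nM, so no number is known for it.
Compound 3, `COc1ccc(/C=C/c2cc(OC)cc(OC)c2/C=C/C(=O)c2cc3cc(Br)ccc3oc2=O)cc1`, gives 12100 nM in this assay.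

Compound 1 and compound 3 are built from the same atoms joined differently: the change is a group of 12 heavy atoms (9 carbon, 2 oxygen, 1 bromine; one six-membered aromatic ring of carbon only, one six-membered aromatic ring with 1 hetero atom) in place of a group of 12 heavy atoms (9 carbon, 2 oxygen, 1 bromine; one six-membered aromatic ring of carbon only, one six-membered aromatic ring with 1 hetero atom), on a carbonyl carbon. That rearrangement gives a 4.0-fold higher number from compound 1 to compound 3 (0.60 log units; beyond the scatter). Compound 1 and compound 2 differ by chloro in place of bromo on an aromatic carbon, and that single swap gives an at least 19-fold higher number from compound 1 to compound 2 (1.29 log units; beyond the scatter). The size of this step is only a lower bound, because of the limit of > 60000 nM in this assay, at which 1 of the 3 values shown sits. Between compound 2 and compound 3 the data show an at least 4.9-fold lower number from compound 2 to compound 3 (0.69 log units; beyond the scatter).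

Compound 4, `COc1ccc(/C=C/c2cc(OC)cc(OC)c2/C=C/C(=O)c2cc3cc(Cl)ccc3oc2=O)cc1`, has not yet been measured. It differs from compound 3 by chloro in place of bromo on an aromatic carbon. The place where the swap occurs is described in the same words as for the swap from compound 1 to compound 2, so this is the same change made on the core of compound 3 instead of the core of compound 1. In this assay compound 4 is therefore expected to show a 9.9-fold higher number from compound 3 to compound 4 (1.00 log units; beyond the scatter), a step of roughly the size seen from compound 1 to compound 2, resting on that one example and on the value of compound 3, 12100 nM. Starting from a weaker compound, compound 4 is estimated at 120000 nM, with a plausible span from 30000 nM to 400000 nM, and it is expected that the assay may again report only a limit.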

Compound 4, half-maximal inhibitory concentration: > 60000 nM
Compound 4: only a limit was reported; the forecaster's own chance of this, stated with the estimate: 75%; the middle value is on the limit's open side.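

Compound 4 reaches only a limit in this assay, > 60000 nM, and that limit is not a number. Chloro in place of bromo on the core of compound 3 gives an at least 4.9-fold higher number from compound 3 to compound 4 (0.69 log units; beyond the scatter), which means weaker inhibition, in the same direction as on the core of compound 1, so across these two cores the direction of the change carries over, while exchanging the whole group on the carbonyl carbon gives an at least 19-fold higher number from compound 1 to compound 4 (1.29 log units; beyond the scatter). The data do not show that the size of the change carries over, since both steps end at a limit and give only a smallest possible size: the same change on two cores in this assay, an at least 19-fold higher number (1.29 log units; beyond the scatter) from compound 1 to compound 2 and an at least 4.9-fold higher number (0.69 log units; beyond the scatter) from compound 3 to compound 4; the limit leaves it open whether they differ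

As far as these compounds go, the step between compound 2 and compound 4 cannot be read, and the two chloro compounds cannot be ranked against each other: the limit of > 60000 nM in this assay, at which 2 of the 4 values shown sit. Whether fluoro, iodo or a methyl group on the same aromatic carbons would keep or lose inhibition stays open, as does whether the step from bromo to chloro would look the same on a core that carries an amine or a carboxylic acid.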